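Replacing chloro with trifluoromethyl in a benzotriazole series

The source may hold more compounds than are shown below. What is called first, only, known or untested is meant among the compounds shown, and "the series" means these compounds.

Measured compounds:
- compound 1, `c1ccc(-c2ccc(Cn3nnc4ccccc43)cc2)cc1`, 12.6 mL/min/g
- compound 2, `Fc1ccc(-c2ccc(Cn3nnc4ccccc43)cc2)c(F)c1`, 6.4 mL/min/g
- compound 3, `Fc1cc(Cl)ccc1-c1ccc(Cn2nnc3ccccc32)cc1`, 1.3 mL/min/g

The measurements come from an ADME assay on microsomes from liver (Rattus norvegicus, strain Wistar) for metabolic stability, tested at 2.5 uM; a lower number here means slower removal, a higher number faster removal of the compound. Among the three measured compounds, compound 3 stands lowest: the numbers are a 4.9-fold lower number from compound 2 to compound 3 (0.69 log units; beyond the scatter) and a 9.7-fold lower number from compound 1 to compound 3 (0.99 log units; beyond the scatter), both steps beyond the scatter, whereas a 2.0-fold lower number from compound 1 to compound 2 (0.29 log units; within the scatter) stays within it.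

Compound 4, `Fc1cc(C(F)(F)F)ccc1-c1ccc(Cn2nnc3ccccc32)cc1`, is not yet measured. It differs from compound 3 in one place: trifluoromethyl in place of chloro on an aromatic carbon. For the measured compounds named here, no measured step involves trifluoromethyl, so the closest guide is the step in which one halogen replaced another on the same ring, a 4.9-fold lower number from compound 2 to compound 3 (0.69 log units; beyond the scatter), which lowered the number, and the larger combined step a 9.7-fold lower number from compound 1 to compound 3 (0.99 log units; beyond the scatter). Whether exchanging chloro for trifluoromethyl continues that movement cannot be read from these three compounds, so for compound 4 the expected step is a 1.3-fold lower number from compound 3 to compound 4 (0.11 log units; within the scatter), small and not clearly beyond the scatter. For compound 4 the estimated value is 1 mL/min/g, with a range from 0.4 mL/min/g to 2.6 mL/min/g.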

Compound 4, intrinsic clearance in a liver preparation (reported as CLH), per the amount of preparation that the assay uses: 0.4 mL/min/g
Compound 4: middle estimate off by 2.5-fold (0.40 log units), on the high side; low and high end bracket the measured number.
By their numbers in this assay, from the lowest: compound 4; then compound 3; then compounds 2 and 1 (each within the scatter of the next).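

Trifluoromethyl in place of chloro at this position, para to a large group, lowers the number in this assay further, a 3.3-fold lower number from compound 3 to compound 4 (0.51 log units; beyond the scatter), so the fall seen with chloro does not stop there. Taken from fluoro at the same position, the change spans a 16-fold lower number from compound 2 to compound 4 (1.20 log units; beyond the scatter), and across these three groups the number falls in the order fluoro, chloro, trifluoromethyl, with no compound here going against that order. Nothing available explains why these exchanges slow removal.

On these data alone, whether the fall continues with a different kind of group at this position, such as an amine, a carboxylic acid or a longer chain, remains open. Also open, as far as these compounds go, is how much the fluoro group on the same ring contributes once trifluoromethyl is present.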